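The compounds below may be only part of what the source reports. "The series", "measured", "known", "first", "only" and "open" are said of these compounds alone.

Compound 1 `COc1ccc(N2CCN(C)CC2)cc1Nc1ncc(F)c(Nc2ccc(F)cc2)n1`: 1130 nM
Compound 2 `O=C(Nc1cccc(Nc2ncc(F)c(Nc3ccc(F)cc3)n2)c1)c1cccc([N+](=O)[O-])c1`: 7250 nM
Compound 3 `O=C(Nc1cc(Cl)cc(Cl)c1)c1cccc(Nc2ncc(F)c(Nc3ccc(F)cc3)n2)c1`: 17500 nM

These values come from a functional assay on A549 cells (Homo sapiens) for antiproliferative activity, read by sulforhodamine B assay, with a stated time of 3 days; on this read-out lower numbers stand for stronger inhibition of growth and higher numbers for weaker inhibition of growth. Compound 2 stands in the middle of the three, with a higher number than compound 1 and a lower number than compound 3, and both gaps lie beyond the usual scatter. Compound 4 `CN(C)CC(=O)Nc1cccc(Nc2ncc(F)c(Nc3ccc(F)cc3)n2)c1` has (dimethylamino)methyl in place of 3-nitrophenyl on a carbonyl carbon. This removes an aromatic ring. Compound 1, whose side group holds no aromatic ring, gives 1130 nM, so a moderate move toward stronger inhibition of growth in this assay is expected, though three compounds are thin support. The expected step runs a 2.9-fold lower number from compound 2 to compound 4 (0.46 log units; beyond the scatter). For compound 4 the estimate is 2500 nM, with an expected range of 700 nM to 8000 nM.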

Compound 4, concentration for 50% growth inhibition: 1180 nM
Estimate against measurement, compound 4: 2.1-fold (0.33 log units) above, and the stated range covers the measured number.
By their numbers in this assay, from the lowest: compounds 1 and 4 (each within the scatter of the next); then compound 2; then compound 3.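

In this assay, putting (dimethylamino)methyl in place of 3-nitrophenyl on the carbonyl carbon gives a 6.1-fold lower number from compound 2 to compound 4 (0.79 log units; beyond the scatter) and shows that this position needs no aromatic ring for growth inhibition. The larger change of (((dimethylamino)methyl)carbonyl)amino in place of (3,5-dichlorophenyl)carbamoyl on an aromatic carbon gives a 15-fold lower number from compound 3 to compound 4 (1.17 log units; beyond the scatter) and points the same way. Nothing measured here explains either step.

As far as these compounds go, it remains open whether the gain comes from the amine nitrogen or simply from losing the ring, which a plain methyl group at this position could separate. A longer chain before the amine, or a cyclic amine such as morpholine, also remains untested in the compounds shown.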